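Widening a Side Chain on a Nucleoside Analogue

A few compounds are considered here, and "the series" means these few. Any claim that something is new, unique, unknown or untested is made for them only; others in the source may bear on it.

Compound 1 `CC(C)(C)c1ccc(Cn2cc(-c3cn([C@H]4C[C@H](O)[C@@H](CO)O4)c(=O)[nH]c3=O)nn2)cc1` and compound 2 `CCCc1cc(-c2cn([C@H]3C[C@H](OC(C)=O)[C@@H](COC(C)=O)O3)c(=O)[nH]c2=O)on1` were both tested in a functional assay on NUGC-3 cells (Homo sapiens) for cytotoxicity, read by sulforhodamine B assay, tested at 10 uM; a higher number here means more inhibition at the concentration tested (going by the name of the read-out), a lower number less inhibition. In this assay compound 1 gives 94.8%, and compound 2 gives 89.1%; the two values lie within the usual scatter of each other, so neither can be called stronger. Compound 3 `CC(=O)OC[C@H]1O[C@@H](n2cc(-c3cc(-c4ccc(C(C)C)cc4)no3)c(=O)[nH]c2=O)C[C@@H]1OC(C)=O` differs from compound 2 by one change: 4-isopropylphenyl in place of propyl on an aromatic carbon. Going by the values given here, no measured pair shows what such a change does, yet compound 1 already carries a similar large aromatic group and stays high. The step of a number 0.9 percentage points higher from compound 2 to compound 3 (within the scatter) is therefore expected to be small or none beyond the scatter. For compound 3 the estimate is 90%, in the range 78% to 98%.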

Compound 3, a percentage reported as inhibition, at one concentration (the size of the read-out at that concentration, not a potency): 56.4%
Estimate against measurement, compound 3: 33.6 percentage points above; the whole stated range lies above it.
By their numbers in this assay, from the lowest: compound 3; then compounds 2 and 1 (each within the scatter of the next).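

In this assay, this place, an aromatic carbon next to the ring nitrogen, does not treat all groups alike: 4-isopropylphenyl in place of propyl gives a number 32.7 percentage points lower from compound 2 to compound 3 (beyond the scatter). The group here can therefore decide much of the inhibition seen, and a six-membered aromatic ring with an isopropyl group can cost a large part of it. Nothing available explains this drop. Going by these compounds, whether a plain phenyl, a longer chain or an amine at this place would keep the inhibition remains open.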